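Aryl replacement on the thiazole of a benzofuran acetic acid

The compounds below may be only part of what the source reports. "The series", "measured", "known", "first", "only" and "open" are said of these compounds alone.

Measured so far:
compound 1, `O=C(O)CC1COc2cc(OCc3nnc(-c4ccccc4)o3)ccc21`: 1.54%
compound 2, `Cc1ccc(-c2nc(C)c(COc3ccc4c(c3)OCC4CC(=O)O)s2)cc1`: 54.9%

In a functional assay on CHO cells for agonist activity at Free fatty acid receptor 1 (Homo sapiens), read by FLIPR and calcium flux, tested at 100 nM (on this read-out lower numbers stand for a weaker effect and higher numbers for a stronger effect at the one concentration tested), compound 2 gives 54.9% and stands highest of the two numbers; compound 1 gives 1.54%, a gap beyond the scatter. Compound 3, `COc1cc(OC)cc(-c2nc(C)c(COc3ccc4c(c3)OCC4CC(=O)O)s2)c1`, is not yet measured. It differs from compound 2 by 3,5-dimethoxyphenyl in place of 4-methylphenyl on an aromatic carbon. For the measured compounds named here, no step between two measured compounds isolates this change, so the direction rests on compound 2 alone. For compound 3 the step of a number 14.9 percentage points lower from compound 2 to compound 3 (beyond the scatter) is expected to be a modest loss, possibly none beyond the scatter. Compound 3 is estimated at 40%, within 10% to 75%.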

Compound 3, a percentage reported as activity, at one concentration (the size of the read-out at that concentration, not a potency): 17.5%
Beside the measured number, compound 3's estimate is 22.5 percentage points above it, within the range that was stated.
By their numbers in this assay, from the lowest: compound 1; then compound 3; then compound 2.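

In this assay, 3,5-dimethoxyphenyl in place of 4-methylphenyl gives a number 37.4 percentage points lower from compound 2 to compound 3 (beyond the scatter), so the aryl group on this five-membered aromatic ring with 1 nitrogen and 1 sulfur clearly affects the read-out. The entering group differs in both size and acceptor count, with 10 heavy atoms and 2 hydrogen-bond acceptors against 7 and 0, and this one step cannot separate the two. No measurement here explains the fall.

Still open, going by these compounds, is whether 4-methoxyphenyl or 4-chlorophenyl at this position would stay level with compound 2.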